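Swapping fluoro for methoxy on a soluble compound

This account rests on a few compounds, and the source may have more. Where it says the series, first, only, none or still open, it means among the compounds named here.

compound 1 `CC(=O)c1cc(-c2ccc(Cl)cc2)n(-c2ccc(S(N)(=O)=O)cc2)c1C` solubility 2700 nM
compound 2 `CCC(=O)c1cc(-c2ccc(C)cc2)n(-c2ccc(S(N)(=O)=O)cc2)c1C` solubility 1000 nM
compound 3 `CCC(=O)c1cc(-c2ccc(S(N)(=O)=O)cc2)n(-c2ccc(F)cc2)n1` solubility 96800 nM

In a physicochemical assay for solubility, read by HPLC, in phosphate buffer, measured as kinetic solubility, at pH 7.4 (a higher number here means a more soluble compound, a lower number a less soluble compound), compound 3 stands highest of the three, and its gaps to compound 1 and compound 2 both lie beyond the scatter. The next compound to be measured is compound 4 `CCC(=O)c1cc(-c2ccc(S(N)(=O)=O)cc2)n(-c2ccc(OC)cc2)n1` and it keeps all of compound 3 except for one place. There, methoxy takes the place of fluoro on an aromatic carbon (methoxy in place of fluoro on an aromatic carbon), which turns 4-fluorophenyl into 4-methoxyphenyl. For the measured compounds named here, no two measured compounds differ in just one place, so the data give no direct guide to this swap. Compound 1 and compound 2 differ from compound 3 in more than one place and say little about it. The best anchor is compound 3 itself at 96800 nM and only a slight drop, not beyond the scatter, is expected. The expected move is a 1.6-fold lower number from compound 3 to compound 4 (0.21 log units; within the scatter) and it remains an estimate. Compound 4 is estimated to give 60000 nM with an expected range of 20000 nM to 150000 nM when it is measured.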

Compound 4, solubility: 64300 nM
Compound 4: the middle estimate sits 1.1-fold (0.03 log units) below what was measured; the measured number falls inside the stated range.
By their numbers in this assay, from the lowest: compound 2; then compound 1; then compounds 4 and 3 (each within the scatter of the next).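

In this assay, for the compounds shown here, methoxy in place of fluoro on an aromatic carbon gives a 1.5-fold lower number from compound 3 to compound 4 (0.18 log units; within the scatter), the first comparison here in which only one place differs. At this place, para to a large group, methoxy brings 2 heavy atoms and 1 hydrogen-bond acceptor where fluoro had 1 heavy atom and no acceptor, yet the two numbers cannot be told apart. Nothing measured here explains why the numbers stay so close.

Still open, on these data alone, is whether an amine, a carboxylic acid or a longer chain such as ethoxy at this place would also stay within the scatter of compound 3. Also open, as far as these compounds go, is whether the same swap would give a similarly small step on the core of compound 1 or the core of compound 2.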